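From benzyloxy to pyrrolidin-1-yl: compound 3 to compound 4

The source may hold more compounds than are shown below. What is called first, only, known or untested is meant among the compounds shown, and "the series" means these compounds.

For the measured compounds named here, in an ADME assay on CCRF-HSB-2 cells (Homo sapiens) for cytotoxicity, with a stated time of 7 days (on this read-out lower numbers stand for higher toxicity in this test and higher numbers for lower toxicity in this test), compound 1 (`CC(C)CSc1nc(N)nc2c1ncn2/C=C1/CC1(CO)CO`) gives the only true number (60000 nM). Compound 2 (`C=CCOc1nc(N)nc2c1ncn2/C=C1/CC1(CO)CO`) is reported only as a limit (> 20000 nM). Compound 3 (`Nc1nc(OCc2ccccc2)c2ncn(/C=C3/CC3(CO)CO)c2n1`) is likewise only a limit (> 20000 nM) and shares with compound 2 the limit of > 20000 nM in this assay, at which 2 of the 3 values shown sit, of the series.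

Compound 4 (`Nc1nc(N2CCCC2)c2ncn(/C=C3/CC3(CO)CO)c2n1`) carries pyrrolidin-1-yl in place of benzyloxy on an aromatic carbon. Exchanges on that same carbon are the nearest guide: a step that the limit leaves unreadable from compound 1 to compound 3 and a step that the limit leaves unreadable from compound 1 to compound 2 give no size, and neither does a step that the two limits leave unreadable from compound 2 to compound 3 for the change within the side group. Going by the values given here, no measured step therefore sets a size or direction here, and only the number for compound 1 (60000 nM) anchors the expectation of weak toxicity in this assay.

The expected step is a step that the limit leaves unreadable from compound 3 to compound 4 and no readable shift is anticipated. Compound 4 is estimated at 40000 nM with an expected range from 15000 nM to 100000 nM. Compound 4 may well give only a limit.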

Compound 4, half-maximal cytotoxic concentration: > 20000 nM
Compound 4 ended at the assay's limit (the forecaster's own chance of this, stated with the estimate: 60%); the middle value is on the limit's open side.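

Compound 4 adds no readable step against compound 1, compound 2 or compound 3 in this assay, since it too gives only a limit: the limit of > 20000 nM in this assay, at which 3 of the 4 values shown sit.

The compounds shown leave open whether any exchange on that aromatic carbon shifts the result in this assay, and by how much.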